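The source may hold more compounds than are shown below. What is called first, only, known or untested is meant among the compounds shown, and "the series" means these compounds.

Results so far in a functional assay on HT-29 cells (Homo sapiens) for cytotoxicity, with a stated time of 72 h; a higher number here means a weaker inhibitor, a lower number a stronger inhibitor

compound 1 `N#Cc1c(-c2ccccc2O)cc(-c2ccc(Br)cc2)[nH]c1=O` gives 21000 nM
compound 2 `N#Cc1c(-c2ccccc2Cl)cc(-c2ccc(Br)cc2)[nH]c1=O` gives "not determined" (no result reported)
compound 3 `N#Cc1c(-c2cccc(Cl)c2)cc(-c2ccc(Br)cc2)[nH]c1=O` gives "not determined" (no result reported)

Compound 3 has no single number in this assay and neither does compound 2, so neither can be ranked against anything else. Among the compounds with values here, the only number available comes from compound 1 at 21000 nM and this compound differs from compound 3 in its hydroxy group where compound 3 carries chloro, so it is not a direct neighbour of compound 3.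

The next compound to be tested is compound 4 `N#Cc1c(-c2cccc(Cl)c2)cc(-c2ccccc2)[nH]c1=O` and it keeps the chlorinated part of compound 3 unchanged. Within the data shown here, the only structural change is hydrogen in place of bromo on an aromatic carbon in which hydrogen replaces bromo on an aromatic carbon, para to a large group, so the 4-bromophenyl becomes phenyl.

Among the measured compounds shown here, no measured pair shows what this replacement does in this assay and the direction of any shift is open. The working expectation is therefore no step beyond the usual scatter, with the level anchored on compound 1 at 21000 nM and held loosely. A result reported only as a limit is also possible.

For compound 4 an estimated 20000 nM is expected, with 5000 nM to 80000 nM as the expected range.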

Compound 4, half-maximal inhibitory concentration: 2100 nM
Estimate against measurement, compound 4: 9.5-fold (0.98 log units) above; measured number below the stated range.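

In this assay compound 4 gives 2100 nM but compound 3 has no single number, so no step can be read between compound 3 and compound 4. The compounds shown leave open what the change from 4-bromophenyl to phenyl does in this series. No supporting evidence bears on this result.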